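Swapping a Hydroxypyrrolidine Ring for an Amino Acid Tail

A few compounds are considered here, and "the series" means these few. Any claim that something is new, unique, unknown or untested is made for them only; others in the source may bear on it.

Measured compounds:
compound 1 `COc1ccc(/C=C\c2cc(OC)c(OC)c(OC)c2)cc1OCc1ccc(CN2CC[C@H](O)C2)cc1` gives 51000 nM
compound 2 `COc1ccc(/C=C\c2cc(OC)c(OC)c(OC)c2)cc1OCc1ccc(CN2CCCCC2C(=O)NCCN)cc1` gives > 50000 nM, a limit
compound 3 `COc1ccc(/C=C\c2cc(OC)c(OC)c(OC)c2)cc1OCc1ccc(CN2CCCCC2C(=O)NCCNC(=O)OC(C)(C)C)cc1` gives 28000 nM

In an ADME assay on NCM460 cells (Homo sapiens) for cytotoxicity, read by CCK-8 assay, with a stated time of 48 h (on this read-out lower numbers stand for stronger inhibition and higher numbers for weaker inhibition), compound 1 gives 51000 nM, the higher of the two numbers shown; compound 3 gives 28000 nM, a gap within the scatter. In this assay compound 2 reaches only a limit, > 50000 nM. Compound 4 `COc1ccc(/C=C\c2cc(OC)c(OC)c(OC)c2)cc1OCc1ccc(CNC(C)(C)C(=O)O)cc1` differs from compound 1 in one place: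
(1-carboxy-1-methylethyl)amino in place of 3-hydroxypyrrolidin-1-yl on a saturated chain carbon bound to an aromatic carbon
Among the compounds with values here, the only measured change at that place, a step that the limit leaves unreadable from compound 1 to compound 2, is unreadable because of the limit of > 50000 nM in this assay, at which 1 of the 3 values shown sits. The step of an at least 1.7-fold lower number from compound 2 to compound 3 (0.25 log units; that floor lies within the scatter) sits elsewhere and within the scatter. No shift beyond the scatter is therefore expected, a 1.0-fold lower number from compound 1 to compound 4 (0.01 log units; within the scatter). Compound 4 is estimated at 50000 nM, between 20000 nM and 110000 nM.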

Compound 4, half-maximal inhibitory concentration: > 50000 nM
Compound 4: a limit, no number (the forecaster's own chance of this, stated with the estimate: 45%); the middle value lies on the limit itself.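

In this assay compound 4 gives > 50000 nM, a limit and not a number. Its steps from compound 1 and compound 2 therefore cannot be read: the limit of > 50000 nM in this assay, at which 2 of the 4 values shown sit. Going by these compounds, whether (1-carboxy-1-methylethyl)amino in place of 3-hydroxypyrrolidin-1-yl shifts this read-out at all stays open.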